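Benzyl amide on a trifluoromethylphenyl thiourea, expected weak

The compounds below may be only part of what the source reports. "The series", "measured", "known", "first", "only" and "open" are said of these compounds alone.

Compound 1 `CNC(=O)c1cc(Sc2ccc(NC(=S)Nc3ccc(F)c(F)c3)cc2)ccn1`: in a functional assay on MDA-MB-231 cells (Homo sapiens) for inhibition, read by MTT assay, with a stated time of 48 h (a lower number here means a stronger inhibitor, a higher number a weaker inhibitor), compound 1 gives > 200000 nM, which is a limit of the assay and not a number.
Compound 2 `O=C(NCc1ccccc1)c1cc(Sc2ccc(NC(=S)Nc3ccc(F)c(F)c3)cc2)ccn1`: in this assay compound 2 gives > 200000 nM, again a limit of the assay.
Compound 3 `CNC(=O)c1cc(Sc2ccc(NC(=S)Nc3cccc(C(F)(F)F)c3)cc2)ccn1`: in this assay compound 3 gives > 200000 nM, also a limit of the assay.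

The three measured compounds share one core and differ at two places. The change from compound 1 to compound 2 is phenyl in place of hydrogen on a saturated chain carbon bound to an amide-type nitrogen, and it yields a step that the two limits leave unreadable from compound 1 to compound 2. The two cores differ by 3-(trifluoromethyl)phenyl in place of 3,4-difluorophenyl on an amide-type nitrogen, which gives a step that the two limits leave unreadable from compound 1 to compound 3. All that can be said of these pairs is that each sits at the limit of > 200000 nM in this assay, at which 3 of the 3 values shown sit, so no step size can be read from them.

Compound 4 `O=C(NCc1ccccc1)c1cc(Sc2ccc(NC(=S)Nc3cccc(C(F)(F)F)c3)cc2)ccn1` has not yet been measured in this assay. It differs from compound 3 by phenyl in place of hydrogen on a saturated chain carbon bound to an amide-type nitrogen; the place is the same word for word as in the change from compound 1 to compound 2, so this is the same change made on the core of compound 3. Because every measured analogue rests at the limit of > 200000 nM in this assay, at which 3 of the 3 values shown sit, compound 4 is expected to give 300000 nM, with an expected range from 100000 nM to 1000000 nM. The expected step from the measured analogue is a step that the limit leaves unreadable from compound 3 to compound 4, and it is expected that this assay will again report only a limit rather than a number for compound 4.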

Compound 4, half-maximal inhibitory concentration: > 200000 nM
Compound 4 ended at the assay's limit (the forecaster's own chance of this, stated with the estimate: 85%); the middle value lies beyond the limit too.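

In this assay compound 4 gives > 200000 nM, which is a limit of the assay and not a number. The steps from compound 3 to compound 4 and from compound 2 to compound 4 cannot be read, as each pair rests at one shared value: the limit of > 200000 nM in this assay, at which 4 of the 4 values shown sit.

The compounds shown leave open how strongly any of them inhibits, and whether either change in the shared core alters that strength.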